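From 2-cyclohexylethyl to cyclohexyl on a carbonyl carbon

This account rests on a few compounds, and the source may have more. Where it says the series, first, only, none or still open, it means among the compounds named here.

Compound 3 (`O=C(CCC1CCCCC1)Nc1ncc(Cc2cccc3nsnc23)s1`) has no number to start from, since in an ADME assay on P388D1 cells (Mus musculus) for cytotoxicity, read by fluorescence and resazurin assay, with a stated time of 72 h (a lower number here means a stronger inhibitor, a higher number a weaker inhibitor), compound 3 shows "not determined" (no result reported) as its entry. Compound 2 (`c1ccc(Cc2cnc(NCCC3CCCCC3)o2)cc1`) is no better placed, with "not determined" (no result reported) as its entry. In this assay compound 1 (`O=C(Nc1ncc(Cc2cccc3sccc23)s1)C1CCCCC1`) gives > 40000 nM as its result, and this is a limit of the assay, not a number. Among the measured compounds shown here, that leaves the limit of > 40000 nM in this assay, at which 1 of the 3 values shown sits, as the only firm reading.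

Compound 4 (`O=C(Nc1ncc(Cc2cccc3nsnc23)s1)C1CCCCC1`) has yet to be measured. One group changes on the way to it (cyclohexyl in place of 2-cyclohexylethyl on a carbonyl carbon), with cyclohexyl in place of 2-cyclohexylethyl on a carbonyl carbon. For the measured compounds named here, no measured step gives a size for this kind of change, so no shift beyond the usual scatter is expected in this assay and no direction can be named. Going by the values given here, the only guide is compound 1, whose limit of > 40000 nM points to weak inhibition. For compound 4 the estimated value is 30000 nM with an expected range from 10000 nM to 80000 nM in this measurement.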

Compound 4, half-maximal inhibitory concentration: > 40000 nM
Compound 4: only a limit was reported; the forecaster's own chance of this, stated with the estimate: 60%; middle value at least 1.3-fold (0.12 log units) away from the limit.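

In this assay compound 4 gives > 40000 nM, a limit of the assay and not a number. Among the compounds shown here, compound 3 has no result to set against it, so no step between them can be read. Whether swapping 2-cyclohexylethyl for cyclohexyl shifts the value stays open, as the only readings shown are limits: the limit of > 40000 nM in this assay, at which 2 of the 4 values shown sit.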